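This account rests on a few compounds, and the source may have more. Where it says the series, first, only, none or still open, it means among the compounds named here.

Measured so far in a functional assay on Hep 3B2 cells (Homo sapiens) for antiproliferative activity, read by MTT assay, with a stated time of 24 h, tested at 11.11 ug/mL; on this read-out higher numbers stand for a stronger effect at the one concentration tested and lower numbers for a weaker effect:
- compound 1 `CCc1ccc2nc(C(=O)Nc3c(F)cc(-c4cccc(F)c4)cc3F)c(C)c(O)c2c1` gives 46.3%
- compound 2 `Cc1ccc2nc(C(=O)Nc3c(F)cc(-c4cccc(F)c4)cc3F)c(C)c(C(=O)O)c2c1` gives 35.6%

Compound 2 stands at the lower of the two numbers in this assay; its nearest neighbour is compound 1, and the gap between the two lies beyond the usual scatter. Among the compounds with values here, the two structures differ in more than one place, so nothing in these two values can be tied to one change alone, and no single-change step between measured compounds exists.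

Compound 3 `CCc1ccc2nc(C(=O)Nc3c(F)cc(-c4cccc(F)c4)cc3F)c(C)c(C(=O)O)c2c1` has not yet been measured. It differs from compound 2 by methyl in place of hydrogen on a saturated chain carbon bound to an aromatic carbon; read one bond further out, the same change is methyl to ethyl. The carboxylic acid of compound 2 is kept. Within the data shown here, with no measured single-change step to lean on, the expectation for compound 3 rests on the value of compound 2 alone, and the step from compound 2 to compound 3 in this assay is expected to be a number 4.4 percentage points higher from compound 2 to compound 3 (within the scatter), none beyond the scatter. Compound 3 is therefore estimated at 40% in this assay, with a range from 25% to 55%.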

Compound 3, a percentage reported as inhibition, at one concentration (the size of the read-out at that concentration, not a potency): 27.2%
For compound 3 the middle estimate is 12.8 percentage points above the measured one; low and high end bracket the measured number.
By their numbers in this assay, from the lowest: compounds 3 and 2 (each within the scatter of the next); then compound 1.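

In this assay the methyl in place of hydrogen on a saturated chain carbon bound to an aromatic carbon gives a number 8.4 percentage points lower from compound 2 to compound 3 (within the scatter) and so, with the carboxylic acid kept, this read-out does not separate the methyl and ethyl forms at this place. Compound 3 also gives the series its first single-change comparison at the other varied place: carboxy in place of hydroxy on an aromatic carbon, with the ethyl kept, gives a number 19.1 percentage points lower from compound 1 to compound 3 (beyond the scatter) and so, unlike the chain change, this modest step stands clear of the scatter. No measurement on these compounds bears on why either step has the size it has.

On these data alone, whether a longer chain such as propyl at the saturated chain carbon would also stay within the scatter of the methyl and ethyl forms remains open. As far as these compounds go, it is equally open how an amine or a methyl ester on the aromatic carbon that carries the hydroxy or carboxy group would compare with these two groups in this assay at the one concentration tested.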